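Swapping the Hydroxy-Methoxyphenyl for a Methoxyphenyl

A few compounds are considered here, and "the series" means these few. Any claim that something is new, unique, unknown or untested is made for them only; others in the source may bear on it.

Three compounds share one core and differ only in the aryl group on a carbonyl carbon. In an in vitro ADME assay on microsomes from liver (Homo sapiens) for metabolic stability (a lower number here means slower removal, a higher number faster removal of the compound), compound 1 `COc1cccc(C(=O)N2CCC(=CC(=O)N[C@@H]3CCN(Cc4ccc5cc(F)ccc5c4)C3)CC2)c1O` gives 162 mL/min/kg. In this assay compound 2 `O=C(C=C1CCN(C(=O)c2ccc(F)cc2)CC1)N[C@@H]1CCN(Cc2ccc3cc(F)ccc3c2)C1` gives 237 mL/min/kg, and compound 3 `COc1cccc(O)c1C(=O)N1CCC(=CC(=O)N[C@@H]2CCN(Cc3ccc4cc(F)ccc4c3)C2)CC1` gives 192 mL/min/kg. Compound 3 therefore stands second highest of the three numbers, yet both the step of a 1.2-fold higher number from compound 1 to compound 3 (0.07 log units; within the scatter) and the step of a 1.2-fold lower number from compound 2 to compound 3 (0.09 log units; within the scatter) lie within the scatter, so compound 3 cannot be told apart from either neighbour on these data.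

Compound 4 `COc1ccc(C(=O)N2CCC(=CC(=O)N[C@@H]3CCN(Cc4ccc5cc(F)ccc5c4)C3)CC2)cc1` differs from compound 3 in one place: 4-methoxyphenyl in place of 2-hydroxy-6-methoxyphenyl on a carbonyl carbon. Going by the values given here, the steps that bear on this are the other aryl exchanges on the same carbonyl carbon: a 1.5-fold higher number from compound 1 to compound 2 (0.17 log units; within the scatter), a 1.2-fold higher number from compound 1 to compound 3 (0.07 log units; within the scatter) and a 1.2-fold lower number from compound 2 to compound 3 (0.09 log units; within the scatter). Each of these stayed within the scatter, whether a hydroxy group was removed, moved or added. The 4-methoxyphenyl itself has not been measured, so the expectation rests only on the indifference of the number to the aryl group seen so far.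

Compound 4 is therefore expected to give about 200 mL/min/kg in this assay, within a range of 120 mL/min/kg to 330 mL/min/kg. The step of a 1.0-fold higher number from compound 3 to compound 4 (0.02 log units; within the scatter) is expected to remain within the scatter.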

Compound 4, clearance: 252 mL/min/kg
Estimate against measurement, compound 4: 1.3-fold (0.10 log units) below, and the stated range covers the measured number.
By their numbers in this assay, from the lowest: compounds 1, 3, 2 and 4 (each within the scatter of the next).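

In this assay, 4-methoxyphenyl in place of 2-hydroxy-6-methoxyphenyl on the carbonyl carbon takes away the hydroxy group and leaves a single methoxy group on the ring, and it gives a 1.3-fold higher number from compound 3 to compound 4 (0.12 log units; within the scatter). Methoxy in place of fluoro on an aromatic carbon gives a 1.1-fold higher number from compound 2 to compound 4 (0.03 log units; within the scatter), while the exchange of 2-hydroxy-3-methoxyphenyl for 4-methoxyphenyl gives a 1.6-fold higher number from compound 1 to compound 4 (0.19 log units; within the scatter), the largest step among the four compounds and still one that does not leave the scatter. Every step among compounds 1, 2, 3 and 4 now lies within the scatter, so across these four aryl groups on this carbonyl carbon, neither the presence of a hydroxy group nor the choice between fluoro and methoxy separates the compounds in this assay.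

No measurement shown here accounts for this indifference to the aryl group. On these data alone, it remains open whether an amine or a carboxylic acid on the phenyl ring, or a longer alkyl chain in place of the aryl group on the same carbonyl carbon, would carry the number beyond the scatter, and whether any change away from this position on the shared core would do so.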